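All ethers at the limit of the membrane potential read-out

A few compounds are considered here, and "the series" means these few. Any claim that something is new, unique, unknown or untested is made for them only; others in the source may bear on it.

Compound 1 `CO[C@H]1CC[C@H]2CCN(C)[C@H]2C1` gives in an assay on HEK293 cells for antagonist activity at Nicotinic acetylcholine receptor alpha-4/beta-2 (Mus musculus), read by FLIPR, using a membrane potential dye (a lower number here means a stronger inhibitor, a higher number a weaker inhibitor), a limit, > 300000 nM.
Compound 2 `CCO[C@H]1CC[C@H]2CCN(C)[C@H]2C1` gives in this assay a limit, > 300000 nM.
Compound 3 `CN1CC[C@@H]2CC[C@H](OCc3ccccc3)C[C@@H]21` gives in this assay a limit, > 300000 nM.

Compound 3 therefore stands only at a limit of this assay, as told by the limit of > 300000 nM in this assay, at which 3 of the 3 values shown sit. The steps among the measured compounds, a step that the two limits leave unreadable from compound 1 to compound 2, a step that the two limits leave unreadable from compound 1 to compound 3 and a step that the two limits leave unreadable from compound 2 to compound 3, give no readable size. Compound 4 `COCCO[C@H]1CC[C@H]2CCN(C)[C@H]2C1` differs from compound 3 by methoxymethyl in place of phenyl on a saturated chain carbon bound to an oxygen on a saturated carbon. All three measured steps concern changes at this same place, and none of them yields a size. No step beyond the scatter is expected in this assay, and compound 4 is expected to remain at the limit. Compound 4 is estimated at 300000 nM, between 100000 nM and 1000000 nM. The expected step is a number no higher from compound 3 to compound 4 (the limit leaves the size open).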

Compound 4, half-maximal inhibitory concentration: > 300000 nM
Compound 4: only a limit was reported; the forecaster's own chance of this, stated with the estimate: 90%; the middle value lies on the limit itself.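

Within the data shown here, compound 4 gives only a limit in this assay, > 300000 nM, and no step between it and compound 1, compound 2 or compound 3 can be read. The compounds shown leave open how these ethers differ in inhibitory strength.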